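Compound 2 to compound 4: replacing the cyclopropyl group

The compounds below may be only part of what the source reports. "The series", "measured", "known", "first", "only" and "open" are said of these compounds alone.

Working notes on a functional assay on U-87MG ATCC cells for cytotoxicity against U-87 MG (Homo sapiens), read by MTT assay, with a stated time of 72 h; on this read-out higher numbers stand for weaker inhibition and lower numbers for stronger inhibition. Across the shared core, compound 1 `COc1ncc(-c2ccc3nc(NC(=O)N(C)C)nn3c2)cc1NS(=O)(=O)c1ccc(F)cc1` gives 1780 nM, compound 2 `COc1ncc(-c2ccc3nc(NC(=O)NC4CC4)nn3c2)cc1NS(=O)(=O)c1ccc(F)cc1` gives 540 nM and compound 3 `COc1ncc(-c2ccc3nc(NC(=O)NCCN(C)C)nn3c2)cc1NS(=O)(=O)c1ccc(F)cc1` gives 980 nM. Among the measured compounds shown here, compound 2 is clearly separated from only one neighbour, as two steps show: a 3.3-fold lower number from compound 1 to compound 2 (0.52 log units; beyond the scatter), and a 1.8-fold higher number from compound 2 to compound 3 (0.26 log units; within the scatter).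

Compound 4 `COc1ncc(-c2ccc3nc(NC(=O)NCC(=O)N4CCOCC4)nn3c2)cc1NS(=O)(=O)c1ccc(F)cc1` keeps the core and changes one group: ((morpholin-4-yl)carbonyl)methyl in place of cyclopropyl on an amide-type nitrogen. In words, ((morpholin-4-yl)carbonyl)methyl stands in place of cyclopropyl on an amide-type nitrogen.

The one measured replacement of cyclopropyl on that nitrogen is a 1.8-fold higher number from compound 2 to compound 3 (0.26 log units; within the scatter), so it offers the closest guide. The other step involving this group, a 3.3-fold lower number from compound 1 to compound 2 (0.52 log units; beyond the scatter), is modest. For the measured compounds named here, no measured compound carries the morpholinyl group, so the guide is weak. A small shift toward a higher number in this assay is expected, and the expected step is a 1.7-fold higher number from compound 2 to compound 4 (0.22 log units; within the scatter). For compound 4 the estimate is 900 nM, with an expected range of 350 nM to 2400 nM.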

Compound 4, half-maximal inhibitory concentration: 3260 nM
Estimate against measurement, compound 4: 3.6-fold (0.56 log units) below, outside the stated range (above it).
By their numbers in this assay, from the lowest: compounds 2, 3, 1 and 4 (each within the scatter of the next, the first and the last beyond it).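

At this amide-type nitrogen the outcome depends on the group that enters: in this assay, ((morpholin-4-yl)carbonyl)methyl in place of cyclopropyl gives a 6.0-fold higher number from compound 2 to compound 4 (0.78 log units; beyond the scatter), beyond the scatter, whereas the 2-(dimethylamino)ethyl group gave a 1.8-fold higher number from compound 2 to compound 3 (0.26 log units; within the scatter), within it. The two larger chains are also separated from each other, with (morpholin-4-yl)carbonyl in place of (dimethylamino)methyl giving a 3.3-fold higher number from compound 3 to compound 4 (0.52 log units; beyond the scatter), while a 1.8-fold higher number from compound 1 to compound 4 (0.26 log units; within the scatter) lies within the scatter, so compound 4 does not keep the advantage that compound 2 holds over compound 1. Nothing measured on these compounds accounts for the shift.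

As far as these compounds go, it remains open whether the higher number follows the morpholine ring or the carbonyl of the chain. A 2-(morpholin-4-yl)ethyl chain or a ((piperidin-1-yl)carbonyl)methyl group on the same nitrogen would separate the two.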